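The source may hold more compounds than are shown below. What is called first, only, known or untested is meant among the compounds shown, and "the series" means these compounds.

Measured so far in a functional assay on SGC-7901 cells (Homo sapiens) for antiproliferative activity, read by MTT assay, with a stated time of 24 h; on this read-out higher numbers stand for weaker inhibition and lower numbers for stronger inhibition:
- compound 1 `Cc1cccc(NNC(=O)c2cccc(NS(=O)(=O)c3cnc(O)nc3O)c2)c1`: > 20000 nM (a limit)
- compound 2 `O=C(NNc1ccccc1Cl)c1cccc(NS(=O)(=O)c2cnc(O)nc2O)c1`: 2270 nM
- compound 3 `Cc1ccccc1C(=O)NNC(=O)c1cccc(NS(=O)(=O)c2cnc(O)nc2O)c1`: > 20000 nM (a limit)

Compound 3 gives > 20000 nM, which is a limit and not a number. It therefore sits at the limit of > 20000 nM in this assay, at which 2 of the 3 values shown sit.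

The compound now in question is compound 4 `O=C(NNC(=O)c1cccc(NS(=O)(=O)c2cnc(O)nc2O)c1)c1cccc(Cl)c1`. Its difference from compound 3 is 3-chlorophenyl in place of 2-methylphenyl on a carbonyl carbon. In words, this is 3-chlorophenyl in place of 2-methylphenyl on a carbonyl carbon.

For the measured compounds named here, no measured step lies at this place, so the evidence is indirect. The first relevant step is an at least 8.8-fold lower number from compound 1 to compound 2 (0.94 log units; beyond the scatter), with 2-chlorophenyl in place of 3-methylphenyl on an amine nitrogen. The second is an at least 8.8-fold higher number from compound 2 to compound 3 (0.94 log units; beyond the scatter), with (2-methylphenyl)carbonyl in place of 2-chlorophenyl on an amine nitrogen. The third, a step that the two limits leave unreadable from compound 1 to compound 3, adds nothing on size.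

Going by the values given here, both readable steps start or end at compound 2, the only chlorine-bearing compound and the only one with a number. With a single such compound, this is a weak guide, and the chlorine sits on a different attachment there. A move toward a lower number is expected, but compound 4 may well remain at the limit.

The estimated step is an at least 1.6-fold lower number from compound 3 to compound 4 (0.22 log units; that floor lies within the scatter).

For compound 4 the estimate is 12000 nM, with an expected range from 3000 nM to 30000 nM.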

Compound 4, half-maximal inhibitory concentration: 7310 nM
Estimate against measurement, compound 4: 1.6-fold (0.22 log units) above; measured number inside the range.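

In this assay, 3-chlorophenyl in place of 2-methylphenyl on a carbonyl carbon gives an at least 2.7-fold lower number from compound 3 to compound 4 (0.43 log units; beyond the scatter), and (3-chlorophenyl)carbonyl in place of 3-methylphenyl on an amine nitrogen gives an at least 2.7-fold lower number from compound 1 to compound 4 (0.43 log units; beyond the scatter); both steps start from a limit of the assay, so only their minimum size can be read, and a carbonyl on this nitrogen does not by itself hold a compound at the limit. The carbonyl-linked group still does not match the directly attached one, since (3-chlorophenyl)carbonyl in place of 2-chlorophenyl on an amine nitrogen gives a 3.2-fold higher number from compound 2 to compound 4 (0.51 log units; beyond the scatter). Across these four compounds, the two bearing chlorine have numbers and the two bearing methyl do not: the limit of > 20000 nM in this assay, at which 2 of the 4 values shown sit.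

Step 3>4 changes both the substituent and its ring position, so the share of each stays unresolved, and 2-chlorophenyl on the carbonyl carbon or 3-chlorophenyl on the amine nitrogen would be needed to separate them. Also open, as far as these compounds go, is how a phenyl ring carrying methoxy, a carboxylic acid or an amine would behave at this position.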